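Three inactive nucleoside analogues and a trifluorophenyl newcomer

The source may report more compounds than this note shows. Statements on the series, on what has been measured and on what is new or still open speak of the compounds shown alone.

Measured so far:
- compound 1, `OC[C@H]1O[C@@H](n2cnc3c(NCc4ccccc4F)ncnc32)[C@H](O)[C@@H]1O`: > 166000 nM
- compound 2, `OC[C@H]1O[C@@H](n2cnc3c(NCc4ccc(Cl)cc4)ncnc32)[C@H](O)[C@@H]1O`: > 166000 nM
- compound 3, `COc1ccccc1CNc1ncnc2c1ncn2[C@@H]1O[C@H](CO)[C@@H](O)[C@H]1O`: > 166000 nM

In a functional assay on B16 cells (Mus musculus) for antiproliferative activity, with a stated time of 72 h (a lower number here means a stronger inhibitor, a higher number a weaker inhibitor), compound 1 gives only a limit of the assay, > 166000 nM, not a number. Compound 2 likewise reaches only the limit > 166000 nM in this assay. Compound 3 also stands at the limit > 166000 nM in this assay, so its place among the three is not readable: all sit at the same limit, as the limit of > 166000 nM in this assay, at which 3 of the 3 values shown sit, records. The measured steps are therefore unreadable: a step that the two limits leave unreadable from compound 1 to compound 2, a step that the two limits leave unreadable from compound 1 to compound 3 and a step that the two limits leave unreadable from compound 2 to compound 3.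

Compound 4, `OC[C@H]1O[C@@H](n2cnc3c(NCc4ccc(F)c(F)c4F)ncnc32)[C@H](O)[C@@H]1O`, differs from compound 3 in one place: 2,3,4-trifluorophenyl in place of 2-methoxyphenyl on a saturated chain carbon bound to a nitrogen on an aromatic ring. For the measured compounds named here, nothing in the measured steps shows that swapping one ring substituent pattern for another moves this assay off its limit, and no step gives a direction or size. The expectation is therefore that compound 4 remains near the limit. For compound 4 the estimated value is 200000 nM, with a range from 50000 nM to 1000000 nM. This expectation means a step that the limit leaves unreadable from compound 3 to compound 4.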

Compound 4, half-maximal inhibitory concentration: > 166000 nM
Compound 4 ended at the assay's limit; the forecaster's own chance of this, stated with the estimate: 85%; the middle value lies beyond the limit too.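

For the compounds shown here, no step among compound 1, compound 2, compound 3 and compound 4 can be read, since each gives a limit rather than a number in this assay: the limit of > 166000 nM in this assay, at which 4 of the 4 values shown sit. The compounds shown leave open whether any ring group on this shared core gives a readable value in this assay.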